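A few compounds are considered here, and "the series" means these few. Any claim that something is new, unique, unknown or untested is made for them only; others in the source may bear on it.

Working notes on the series, with all readings taken from a functional assay on HCT-116 cells (Homo sapiens) for cytotoxicity (a higher number here means a weaker inhibitor, a lower number a stronger inhibitor), as the common measure. Compound 1 `COC(=O)C1C(c2oc(=O)c(CO)c(OC)c2CO)C(C(=O)OC)C1c1oc(=O)c(CO)c(OC)c1CO` gives > 50000 nM as its reading, which is a limit and not a number. Compound 2 `COC(=O)/C=C/c1oc(=O)c(COC(C)=O)c(OC)c1CO` reads 2310 nM in this test. Compound 3 `COC(=O)/C=C/c1oc(=O)c(CO)c(OC)c1COC(C)=O` reads 9840 nM and so holds the higher of the two actual numbers, with its gap to compound 2 lying beyond the scatter.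

The next step leads to compound 4 `COC(=O)/C=C/c1oc(=O)c(COC(C)=O)c(OC)c1COC(C)=O` in which the hydroxymethyl of compound 3 becomes acetoxymethyl. This is acetyl in place of hydrogen on an oxygen on a saturated carbon, counted as acetyl in place of hydrogen on an oxygen on a saturated carbon for the change.

Going by the values given here, no measured step isolates this change, so the expectation rests on the few values in hand. Compound 2 at 2310 nM shows that a number lower than that of compound 3 is reachable in this series, so a drop is expected rather than a rise. The estimated move in this assay is a 3.9-fold lower number from compound 3 to compound 4 (0.60 log units; beyond the scatter) and would be a modest gain in strength. For compound 4 the expected value is 2500 nM with 700 nM to 9000 nM as the estimated range.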

Compound 4, half-maximal inhibitory concentration: 1320 nM
For compound 4 the middle estimate is 1.9-fold (0.28 log units) above the measured one, and the stated range covers the measured number.
By their numbers in this assay, from the lowest: compounds 4 and 2 (each within the scatter of the next); then compound 3. At a limit, above all of these: compound 1.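

In this assay, going by these compounds alone, acetyl in place of hydrogen on the hydroxymethyl that compound 3 still carries gives a 7.5-fold lower number from compound 3 to compound 4 (0.87 log units; beyond the scatter), the first single-place step and one that lies beyond the scatter. The same kind of change on the hydroxymethyl that compound 2 still carries gives a 1.8-fold lower number from compound 2 to compound 4 (0.24 log units; within the scatter), which lies within the scatter, so the two hydroxymethyl groups do not answer alike to acetylation: one step is clear, while the other cannot be told from repeat noise. The readings in hand offer no measured property that would explain this difference between the two steps.

The compounds shown leave open how the reading would respond to a longer chain, such as butyryl, in place of acetyl on either oxygen, or to an amine in place of the acetoxy group. Also open, as far as these compounds go, is the reading of a counterpart of compound 4 with hydrogen in place of both acetyl groups, which would complete the set of single-place steps around compound 2 and compound 3.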